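Oxime ether series: ethoxy added to the aryl piperazine

This account rests on a few compounds, and the source may have more. Where it says the series, first, only, none or still open, it means among the compounds named here.

For the measured compounds named here, compound 2 `CCO/N=C(\CCN1CCN(c2ccccc2)CC1)c1ccccc1` gives the higher of the two numbers measured so far: in a functional assay on HEK293 cells with D(4) dopamine receptor (Homo sapiens) as the target, read by FLIPR (on this read-out lower numbers stand for an effect already at smaller amounts and higher numbers for an effect only at larger amounts of compound), compound 2 gives 109 nM, whereas compound 1 `Cc1cccc(/C(CCN2CCN(c3ccccn3)CC2)=N/O)c1` gives 2.3 nM, a gap beyond the scatter. Compound 3 `CCO/N=C(\CCN1CCN(c2cccc(OCC)c2)CC1)c1ccccc1` differs from compound 2 in one place, (ethoxy in place of hydrogen on an aromatic carbon), on an aromatic carbon of a six-membered aromatic ring of carbon only. Going by the values given here, no step between measured compounds bears on this change, so compound 3 is expected to shift only modestly toward lower numbers, a step of a 1.8-fold lower number from compound 2 to compound 3 (0.26 log units; within the scatter) near the edge of the scatter. Compound 3 is estimated at 60 nM, within 15 nM to 250 nM.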

Compound 3, half-maximal effective concentration: 347 nM
Compound 3: the middle estimate sits 5.8-fold (0.76 log units) below what was measured; measured number outside the range, above it.
By their numbers in this assay, from the lowest: compound 1; then compound 2; then compound 3.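

In this assay, ethoxy in place of hydrogen on an aromatic carbon, meta to a large group, gives a 3.2-fold higher number from compound 2 to compound 3 (0.50 log units; beyond the scatter), a modest step beyond the scatter. This first step at this position shows that, for this pair, 3-ethoxyphenyl needs larger amounts of compound for an effect than phenyl does. Nothing available explains the shift.

Going by these compounds, whether methoxy, a hydroxyl or a fluorine atom at the same place would move the number the same way remains open. So does whether a longer chain than ethoxy would extend the step.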